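A few compounds are considered here, and "the series" means these few. Any claim that something is new, unique, unknown or untested is made for them only; others in the source may bear on it.

Going by the values given here, in an ADME assay on Vero cells (Chlorocebus sabaeus) for cytotoxicity, read by MTT assay, with a stated time of 96 h (a higher number here means that more compound is tolerated, a lower number that less compound is tolerated), only two compounds have results so far, and neither result is an exact number. Compound 1 `CC(=O)c1ccc2[nH]c(-c3ccc(C(F)(F)F)cc3)nc2c1` gives > 100000 nM, which is a limit of the assay. Compound 2 `C/C(=N\NC(N)=S)c1ccc2[nH]c(-c3ccc(Cl)cc3)nc2c1` gives > 100000 nM, which is also a limit. Compound 2 therefore stands at the limit of > 100000 nM in this assay, at which 2 of the 2 values shown sit.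

Compound 3 `C/C(=N\NC(N)=S)c1ccc2[nH]c(-c3ccc(C(F)(F)F)cc3)nc2c1` differs from compound 2 in one place, with trifluoromethyl in place of chloro on an aromatic carbon, para to a large group: trifluoromethyl in place of chloro on an aromatic carbon. Compound 1 already carries trifluoromethyl and gives > 100000 nM, again a limit, so this swap is not expected to produce a change beyond the usual scatter in this assay. The expected step of a number no higher from compound 2 to compound 3 (the limit leaves the size open) is small and has no clear direction. Compound 3 is estimated at 100000 nM, with an expected range from 40000 nM to 200000 nM.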

Compound 3, half-maximal cytotoxic concentration: 22000 nM
The estimate for compound 3 lay 4.5-fold (0.66 log units) above the measured number; the measured number lies below the stated range.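

Trifluoromethyl in place of chloro on the aromatic carbon para to a large group brings an at least 4.5-fold lower number from compound 2 to compound 3 (0.65 log units; beyond the scatter) in this assay, so this position can affect how much compound the cells tolerate. Trifluoromethyl alone does not bring this, as the group of 7 heavy atoms in place of the group of 3 heavy atoms on another aromatic carbon, with trifluoromethyl kept, brings an at least 4.5-fold lower number from compound 1 to compound 3 (0.65 log units; beyond the scatter). Both steps start from a limit, so their true sizes stay open, and only the two groups together in compound 3 give an exact number: the limit of > 100000 nM in this assay, at which 2 of the 3 values shown sit.

As far as these compounds go, whether a methoxy group or an amine at this position would give a number like that of compound 2 or of compound 3 remains open. What lies behind the lower number also remains open.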